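The source may hold more compounds than are shown below. What is called first, only, known or untested is meant among the compounds shown, and "the series" means these compounds.

Measured in an ADME assay on Vero cells (Chlorocebus sabaeus) for cytotoxicity, read by MTT assay, with a stated time of 72 h; a higher number here means that more compound is tolerated, a lower number that less compound is tolerated:
compound 1 `CC1CC(C)(C)CC(O)(c2nnc(-c3ccncc3)[nH]2)C1` gives 414 ug/mL;
compound 2 `CC1CC(C)(C)CC(O)(c2nnc(-c3cccnc3)[nH]2)C1` gives 368 ug/mL;
compound 3 `OC(c1nnc(-c2ccncc2)[nH]1)C1CC=CCC1` gives 388 ug/mL.

Compound 4 `OC(c1nnc(-c2cccnc2)[nH]1)C1CC=CCC1` has not yet been measured in this assay. It differs from compound 3 by pyridin-3-yl in place of pyridin-4-yl on an aromatic carbon. The same kind of change separates compound 1 from compound 2, (pyridin-3-yl in place of pyridin-4-yl on an aromatic carbon), where the place is described as bearing a large group rather than a group of 8 heavy atoms; that change gave a 1.1-fold lower number from compound 1 to compound 2 (0.05 log units; within the scatter). The difference between the cores of compound 1 and compound 3 is not broken down here, and their values in this assay lie within the scatter of each other. Because the earlier step was a 1.1-fold lower number from compound 1 to compound 2 (0.05 log units; within the scatter), the step from compound 3 to compound 4 is expected to be similarly small, about a 1.1-fold lower number from compound 3 to compound 4 (0.03 log units; within the scatter). Compound 4 is therefore estimated at 360 ug/mL in this assay, with a likely range from 250 ug/mL to 520 ug/mL.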

Compound 4, half-maximal cytotoxic concentration: 371 ug/mL
Estimate against measurement, compound 4: 1.0-fold (0.01 log units) below; low and high end bracket the measured number.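

In this assay, putting pyridin-3-yl in place of pyridin-4-yl gave a 1.0-fold lower number from compound 3 to compound 4 (0.02 log units; within the scatter). The change carried over from one core to the other with no difference that can be told apart, as the two steps show: the same change on two cores in this assay, a 1.1-fold lower number (0.05 log units; within the scatter) from compound 1 to compound 2 and a 1.0-fold lower number (0.02 log units; within the scatter) from compound 3 to compound 4, 1.1-fold (0.03 log units) apart, within the scatter of two such steps

For the compounds shown here, this shows only that the swap stays within the scatter on these two cores; it does not show how a step of real size would carry over, nor how the swap would behave on other cores.

The compounds shown leave open whether a different group at this place, such as an amine or a carboxylic acid, would move the number beyond the scatter. Also open, going by these compounds, is what a longer chain in place of the hydroxyl would do.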